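The source may hold more compounds than are shown below. What is called first, only, known or untested is meant among the compounds shown, and "the series" means these compounds.

Compound 1 `C/C(=N\NC(N)=O)c1ccc2c(c1)nc(-c1ccoc1)n2C1CCCCC1`: "not determined" (no result reported)
Compound 2 `C/C(=N\NC(N)=S)c1ccc2c(c1)nc(-c1ccc(Cl)cc1)n2C1CCCCC1`: > 100000 nM
Compound 3 `C/C(=N\NC(N)=S)c1ccc2c(c1)nc(-c1ccc(C(F)(F)F)cc1)n2C1CCCCC1`: > 100000 nM

In an ADME assay on Vero cells (Chlorocebus sabaeus) for cytotoxicity, read by MTT assay, with a stated time of 96 h (a higher number here means that more compound is tolerated, a lower number that less compound is tolerated), compound 3 gives > 100000 nM, which is a limit of the assay and not a number. The same holds for compound 2, as the limit of > 100000 nM in this assay, at which 2 of the 3 values shown sit, shows. Compound 4 `C/C(=N\NC(N)=S)c1ccc2c(c1)nc(-c1ccoc1)n2C1CCCCC1` carries furan-3-yl in place of 4-(trifluoromethyl)phenyl on an aromatic carbon. Compound 1 also carries furan-3-yl but offers no result to compare. Among the compounds with values here, the only measured step is a step that the two limits leave unreadable from compound 2 to compound 3, so it gives no size to carry over. No change beyond the scatter is therefore expected in this assay, in either direction, and the expected step is a number no higher from compound 3 to compound 4 (the limit leaves the size open). Compound 4 is estimated at 100000 nM, with an expected range of 40000 nM to 200000 nM.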

Compound 4, half-maximal cytotoxic concentration: 25000 nM
Compound 4: middle estimate off by 4.0-fold (0.60 log units), on the high side; measured number outside the range, below it.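

In this assay, the group on the aromatic carbon between two ring nitrogen atoms now proves able to change the tolerated concentration, something the unreadable step between the two earlier aryl compounds could not show. Furan-3-yl gives an at least 4.0-fold lower number from compound 3 to compound 4 (0.60 log units; beyond the scatter), and it gives an at least 4.0-fold lower number from compound 2 to compound 4 (0.60 log units; beyond the scatter). Compound 2 and compound 3 both stand at a limit of the assay, so these sizes are minimums: the limit of > 100000 nM in this assay, at which 2 of the 4 values shown sit.

On these data alone, what remains open is whether the smaller ring or its oxygen matters more. Unsubstituted phenyl or thiophen-3-yl at this position could help separate the two.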